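Thioether chain variation in a TRPV1 antagonist series

This account rests on a few compounds, and the source may have more. Where it says the series, first, only, none or still open, it means among the compounds named here.

Measured so far: compound 1 `CCC1CCN(c2nc(C(C)(C)C)ccc2CNC(=O)C(C)c2ccc(NS(C)(=O)=O)c(F)c2)CC1` gives 0.1 nM; compound 2 `CCCCOc1nc(C(C)(C)C)ccc1CNC(=O)C(C)c1ccc(NS(C)(=O)=O)c(F)c1` gives 0.9 nM; compound 3 `CCCCCSc1nc(C(C)(C)C)ccc1CNC(=O)C(C)c1ccc(NS(C)(=O)=O)c(F)c1` gives 3.1 nM, all in an assay on cells for antagonist activity at transient receptor potential cation channel subfamily V member 1 (Homo sapiens), read by FLIPR and calcium flux, with a stated time of 6 min; a lower number here means a stronger inhibitor, a higher number a weaker inhibitor.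

Compound 3 holds the highest number of the three, a 3.4-fold higher number from compound 2 to compound 3 (0.54 log units; beyond the scatter) and a 31-fold higher number from compound 1 to compound 3 (1.49 log units; beyond the scatter). The next compound, compound 4 `CC(C(=O)NCc1ccc(C(C)(C)C)nc1SCc1ccccc1Cl)c1ccc(NS(C)(=O)=O)c(F)c1`, keeps the sulfur link of compound 3 and changes the chain on it: 2-chlorophenyl in place of butyl on a saturated chain carbon bound to a sulfur. Among the measured compounds shown here, no measured step tests an aromatic ring in this position; the nearest precedent is the chain swap a 3.4-fold higher number from compound 2 to compound 3 (0.54 log units; beyond the scatter), which was modest, while a 9.0-fold higher number from compound 1 to compound 2 (0.95 log units; beyond the scatter) concerns the linking atom rather than the chain. A step within the scatter in this assay is therefore expected, a 1.0-fold lower number from compound 3 to compound 4 (0.01 log units; within the scatter). Compound 4 is estimated at 3 nM, with a range of 1 nM to 10 nM.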

Compound 4, inhibition constant: 3.8 nM
Compound 4: the middle estimate sits 1.3-fold (0.10 log units) below what was measured; the measured number falls inside the stated range.
By their numbers in this assay, from the lowest: compound 1; then compound 2; then compounds 3 and 4 (each within the scatter of the next).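

On a saturated chain carbon bound to a sulfur, 2-chlorophenyl in place of butyl brings in an aromatic ring, yet a 1.2-fold higher number from compound 3 to compound 4 (0.09 log units; within the scatter) in this assay shows that this position tolerates the ring as well as the butyl chain. Relative to the other two compounds, the (2-chlorobenzyl)sulfanyl group gives a 4.2-fold higher number from compound 2 to compound 4 (0.63 log units; beyond the scatter) against butoxy and a 38-fold higher number from compound 1 to compound 4 (1.58 log units; beyond the scatter) against 4-ethylpiperidin-1-yl, so it remains short of both. No measurement shown offers an explanation for these steps.

Still open, from the compounds shown here alone, is how an unsubstituted benzyl on the sulfur would compare with 2-chlorobenzyl. An amine or a carboxylic acid at the end of the sulfur chain also remains untested by the compounds shown.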